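Methyl Added to the Thioether Semicarbazone

The compounds below may be only part of what the source reports. "The series", "measured", "known", "first", "only" and "open" are said of these compounds alone.

Two semicarbazones of diaryl-linked benzaldehyde or acetophenone type have been run in a functional assay on the whole organism with Mus musculus as the target, with a stated time of 1 h; on this read-out higher numbers stand for an effect only at larger amounts of compound and lower numbers for an effect already at smaller amounts. Compound 1 `C/C(=N/NC(N)=O)c1ccc(Oc2ccc(C)cc2)cc1` gives 18.7 mg/kg in this assay. Compound 2 `NC(=O)N/N=C/c1ccc(Sc2ccccc2)cc1` reaches only the limit of this assay, > 46 mg/kg, so no number stands for it; this limit is the limit of > 46 mg/kg in this assay, at which 1 of the 2 values shown sits. Within the data shown here, no single-point step connects compound 1 and compound 2, and their two values are taken as they are.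

Compound 3 `Cc1ccc(Sc2ccc(/C=N/NC(N)=O)cc2)cc1` has not yet been measured in this assay. It differs from compound 2 by methyl in place of hydrogen on an aromatic carbon. Among the measured compounds shown here, the change is one heavy atom, and no measured step shows what a methyl at this place does, so the expected step is taken as small and of uncertain direction. Compound 3 is expected to show 40 mg/kg in this assay, within a range of 15 mg/kg to 100 mg/kg. The expected step from compound 2 to compound 3 is thus an at least 1.1-fold lower number from compound 2 to compound 3 (0.06 log units; that floor lies within the scatter), with a real chance that compound 3 again stops at the limit of this assay.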

Compound 3, dose for half-maximal effect: > 300 mg/kg
Compound 3: a limit, no number; the forecaster's own chance of this, stated with the estimate: 50%; at least 7.5-fold (0.87 log units) between middle value and limit.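

Among these compounds, compound 2 and compound 3 both end at limits, not numbers, in this assay, so no step between them can be read. The compounds shown leave open both the direction and the size of the effect of methyl in place of hydrogen on an aromatic carbon.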